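This account rests on a few compounds, and the source may have more. Where it says the series, first, only, none or still open, it means among the compounds named here.

In a functional assay on the whole organism (stomach) with Rattus norvegicus as the target (on this read-out higher numbers stand for an effect only at larger amounts of compound and lower numbers for an effect already at smaller amounts), compound 1 `CCCCCC/N=C/N1CCC(C(c2ccccc2)c2ccccc2)CC1` gives 8.34 mg/kg, and compound 2 `C=CC/N=C/N1CCC(C(c2ccccc2)c2ccccc2)CC1` gives 10.4 mg/kg. Going by the values given here, these are the only two numbers, and a 1.2-fold higher number from compound 1 to compound 2 (0.10 log units; within the scatter), so compound 1 cannot be separated from its sole neighbour. Compound 3 `CCCCCCC/N=C/N1CCC(C(c2ccccc2)c2ccccc2)CC1` differs from compound 1 by methyl in place of hydrogen on a saturated chain carbon, six bonds along the chain from a double-bonded nitrogen. Among the compounds with values here, no measured pair tests this exact change. The nearest evidence is the chain change between compound 1 and compound 2, where a 1.2-fold higher number from compound 1 to compound 2 (0.10 log units; within the scatter). A step within the scatter is therefore expected in this assay, with no firm direction. Compound 3 is expected at 9 mg/kg, with an estimated range of 4.5 mg/kg to 18 mg/kg. The expected change is a 1.1-fold higher number from compound 1 to compound 3 (0.03 log units; within the scatter).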

Compound 3, dose for half-maximal effect: 11.5 mg/kg
The estimate for compound 3 lay 1.3-fold (0.11 log units) below the measured number; measured number inside the range.
By their numbers in this assay, from the lowest: compounds 1, 2 and 3 (each within the scatter of the next).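

Methyl in place of hydrogen on a saturated chain carbon, six bonds along the chain from a double-bonded nitrogen, now has a direct reading in this assay (a 1.4-fold higher number from compound 1 to compound 3 (0.14 log units; within the scatter)), and this step does not separate the two compounds. Hexyl in place of vinyl on a saturated chain carbon bound to a double-bonded nitrogen also stays unresolved (a 1.1-fold higher number from compound 2 to compound 3 (0.04 log units; within the scatter)), so all three chains tested so far lie within the scatter of the next. No measured evidence bears on these results.

Going by these compounds, whether any change to this chain can move the dose beyond the scatter remains open. A longer chain, or an amine or a carboxylic acid on the chain, would test this, and the compounds shown give no indication of the outcome.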